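Trifluoromethoxy in Place of Methoxy on a Cyclopropane Hydrazide

The compounds below may be only part of what the source reports. "The series", "measured", "known", "first", "only" and "open" are said of these compounds alone.

Measured compounds:
compound 1, `CCOc1ccc(C2CC2C(=O)NNC(=O)c2ccncc2)cc1`: 43000 nM
compound 2, `COc1ccc(C2CC2C(=O)NNc2nncc3ccccc23)cc1`: 96000 nM

Of the compounds shown here, two have been measured so far. In a functional assay on A549 cells (Homo sapiens) for inhibition, read by MTT assay, with a stated time of 72 h (a lower number here means a stronger inhibitor, a higher number a weaker inhibitor), compound 1 gives 43000 nM, and compound 2 gives 96000 nM. Compound 2 thus stands at the higher of the two numbers, and the gap to compound 1 lies beyond the usual scatter, so compound 2 is the weaker inhibitor of the pair. The two compounds differ in more than one place, so no single-change step can be read from them.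

Compound 3, `O=C(NNc1nncc2ccccc12)C1CC1c1ccc(OC(F)(F)F)cc1`, differs from compound 2 in one place only: trifluoromethyl in place of methyl on an oxygen on an aromatic ring. For the measured compounds named here, no measured pair shows what this change does here, so any expectation rests on the weak starting point alone. The step of a 1.6-fold lower number from compound 2 to compound 3 (0.20 log units; within the scatter) is expected to be small, in either direction, and may not exceed the scatter. For compound 3 the estimate in this assay is 60000 nM, with a plausible range from 20000 nM to 200000 nM.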

Compound 3, half-maximal inhibitory concentration: 87000 nM
The estimate for compound 3 lay 1.5-fold (0.16 log units) below the measured number; the range from low to high includes it.
By their numbers in this assay, from the lowest: compound 1; then compounds 3 and 2 (each within the scatter of the next).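

At the oxygen on the aromatic ring, trifluoromethyl in place of methyl gives a 1.1-fold lower number from compound 2 to compound 3 (0.04 log units; within the scatter) in this assay, so this read-out does not separate the two compounds. For the compounds shown here, this is the first step that changes one place alone, and it shows that methoxy to trifluoromethoxy, with trifluoromethyl bringing more heavy atoms than methyl, makes no difference that can be told from the scatter, and that the number stays in the same high range with either group. Nothing on hand bears on why this exchange leaves the reading so close.

As far as these compounds go, whether any group on that oxygen can move the number beyond the scatter stays open, since a longer chain such as butyl there, or a carboxylic acid on the aromatic ring, might behave quite differently from these two groups. The compounds shown also offer no single-place step anywhere else on the shared core, so what its other parts contribute to the reading in this assay remains unknown.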